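Bromo to chloro swap on the phenoxy ring: expected step

The compounds below may be only part of what the source reports. "The series", "measured", "known", "first", "only" and "open" are said of these compounds alone.

Four close analogues share a spiro core carrying a phenoxypropyloxy arm. Compound 1 `NC1=NC2(CCOCC2)N(OCCCOc2ccccc2Cl)C(N)=N1` and compound 2 `NC1=NC2(CCOCC2)N(OCCCOc2ccccc2Br)C(N)=N1` differ only in the halogen on the aromatic ring, 2-chlorophenoxy against 2-bromophenoxy. Compound 3 `NC1=NC2(CCSCC2)N(OCCCOc2ccccc2Br)C(N)=N1` carries the bromo group on a different core; the difference between the core of compound 3 and the core of compound 2 is not broken down here. Compound 4 `NC1=NC2(CCSCC2)N(OCCCOc2ccccc2Cl)C(N)=N1` is the chloro counterpart of compound 3 and has not yet been measured.

In a functional assay on HL-60 cells (Homo sapiens) for antiproliferative activity, read by MTT assay, with a stated time of 72 h (a lower number here means a stronger inhibitor, a higher number a weaker inhibitor), compound 1 gives 660 nM, and compound 2 gives 610 nM. The change chloro in place of bromo on an aromatic carbon produces a 1.1-fold higher number from compound 2 to compound 1 (0.03 log units; within the scatter), so the two halogens give numbers that cannot be told apart in this assay. Compound 3 gives 180 nM, a number well below those of compound 1 and compound 2.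

The change from compound 3 to compound 4, (chloro in place of bromo on an aromatic carbon), is the same change as that from compound 2 to compound 1: both place lines read identically, on an aromatic carbon of a six-membered aromatic ring of carbon only, ortho to a large group. The expectation therefore rests on that single earlier step, because a 1.1-fold higher number from compound 2 to compound 1 (0.03 log units; within the scatter) shows the swap to be essentially neutral. Compound 4 is expected to give a 1.1-fold higher number from compound 3 to compound 4 (0.05 log units; within the scatter) against compound 3. The estimated value of compound 4 in this assay is 200 nM, with a likely range from 100 nM to 400 nM.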

Compound 4, half-maximal inhibitory concentration: 390 nM
Compound 4: middle estimate off by 2.0-fold (0.29 log units), on the low side, and the stated range covers the measured number.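

In this assay, chloro in place of bromo on an aromatic carbon, ortho to a large group, gives a 2.2-fold higher number from compound 3 to compound 4 (0.34 log units; beyond the scatter), a modest step that lies beyond the scatter on the core of compound 3. Set beside the same change on the core of compound 2, this step cannot be separated from the earlier one: the same change on two cores in this assay, a 1.1-fold higher number (0.03 log units; within the scatter) from compound 2 to compound 1 and a 2.2-fold higher number (0.34 log units; beyond the scatter) from compound 3 to compound 4, 2.0-fold (0.30 log units) apart, within the scatter of two such steps. Among the compounds shown here, the two cores are therefore compatible with a single shared effect of the swap, but with only one pair on each core, this neither proves that the effect carries over unchanged nor shows that the core alters it, and the step on one core being within the scatter and the other beyond it is no evidence of a real difference between them.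

Still open, as far as these compounds go, is whether fluoro, iodo or methyl on the same aromatic carbon would follow the 2-bromophenoxy and 2-chlorophenoxy pairs, and whether the halogen swap would behave alike with a longer chain in the arm. Also open is how the swap would read on a core other than the two shown, such as one carrying an amine in its saturated ring.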